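This account rests on a few compounds, and the source may have more. Where it says the series, first, only, none or still open, it means among the compounds named here.

Compound 1 `O=C(/C(=C\c1ccc(Br)cc1)Sc1ccc(Br)cc1)c1ccc(Br)cc1` and compound 3 `O=C(/C(=C\c1ccc(I)cc1)Sc1ccc(Br)cc1)c1ccc(Br)cc1` share one core and differ only in a single halogen. In a functional assay on DU-145 cells (Homo sapiens) for inhibition, read by trypan blue exclusion, with a stated time of 96 h (on this read-out lower numbers stand for stronger inhibition of growth and higher numbers for weaker inhibition of growth), compound 1 gives 1000 nM, and in this assay compound 3 gives 1000 nM. The change between them is iodo in place of bromo on an aromatic carbon, and it produced no change at the digits printed from compound 1 to compound 3 (within the scatter). Compound 2 `O=C(/C(=C/c1ccc(I)cc1)S(=O)(=O)Cc1ccc(I)cc1)c1ccc(Br)cc1` carries a different core; how it differs from compound 1 is not broken down here. In this assay compound 2 gives 20000 nM, the highest of the three numbers, beyond the scatter from both compound 1 and compound 3.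

Compound 4 `O=C(/C(=C/c1ccc(I)cc1)S(=O)(=O)Cc1ccc(I)cc1)c1ccc(I)cc1` is not yet measured. It arises from compound 2 by iodo in place of bromo on an aromatic carbon, the same change as from compound 1 to compound 3, though here it reads one bond further out as (4-bromophenyl)carbonyl to (4-iodophenyl)carbonyl. Because the step of no change at the digits printed from compound 1 to compound 3 (within the scatter) stayed within the scatter, the expected step is no change at the digits printed from compound 2 to compound 4 (within the scatter), resting on that single earlier example. The estimate for compound 4 in this assay is therefore 20000 nM, expected between 8000 nM and 50000 nM.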

Compound 4, concentration for 50% growth inhibition: 50000 nM
Estimate against measurement, compound 4: 2.5-fold (0.40 log units) below; the measured number falls inside the stated range.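

On the core of compound 2, iodo in place of bromo on the aromatic carbon of the (4-bromophenyl)carbonyl group gives a 2.5-fold higher number from compound 2 to compound 4 (0.40 log units; beyond the scatter) in this assay. Set beside the same change on the core of compound 1, the two steps do not differ by more than repeated measurements of two such steps would be expected to: the same change on two cores in this assay, no change at the digits printed (within the scatter) from compound 1 to compound 3 and a 2.5-fold higher number (0.40 log units; beyond the scatter) from compound 2 to compound 4, 2.5-fold (0.40 log units) apart, within the scatter of two such steps This supports carrying the swap between these two cores as a small change in growth inhibition, but it rests on only two pairs of compounds and does not show that the step would be the same on a third core, nor does it explain why the number rises on one core and not on the other.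

As far as these compounds go, only bromo and iodo appear at this place, so it remains open whether a chloro group, a methoxy group or an amine on that ring carbon would leave the number as little changed. From the compounds shown here alone, it also remains open whether a carboxylic acid there would give a step of similar size on both cores.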